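The compounds below may be only part of what the source reports. "The series", "measured", "known", "first", "only" and "open" are said of these compounds alone.

Compound 3 `CCCN(CC[C@H]1CC[C@H](NS(=O)(=O)c2ccc(C(C)C)cc2)CC1)[C@H]1CCc2nc(N)sc2C1` gives 4.5 nM in an assay on brain for displacement of a labelled ligand from D(3) dopamine receptor (Rattus norvegicus) (a higher number here means a weaker inhibitor, a lower number a stronger inhibitor), the second highest of the three numbers measured. Compound 2 `CCCN(CC[C@H]1CC[C@H](NS(=O)(=O)c2cccc(C)c2)CC1)[C@H]1CCc2nc(N)sc2C1` gives 0.89 nM, and compound 1 `CCCN(CC[C@H]1CC[C@H](NC(=O)/C=C/c2cccc(F)c2)CC1)[C@H]1CCc2nc(N)sc2C1` gives 9.9 nM. Among the measured steps there is an 11-fold lower number from compound 1 to compound 2 (1.05 log units; beyond the scatter) and there is a 5.1-fold higher number from compound 2 to compound 3 (0.70 log units; beyond the scatter). Compound 4 `CCCN(CC[C@H]1CC[C@H](NS(=O)(=O)c2ccc(Cl)nc2)CC1)[C@H]1CCc2nc(N)sc2C1` differs from compound 3 by 6-chloropyridin-3-yl in place of 4-isopropylphenyl on a sulfonyl sulfur. Among the measured compounds shown here, the step from compound 2 to compound 3, which also exchanges the group on the sulfonyl sulfur, is the one that bears on this change, and it was modest; no measured step shows a pyridinyl group at this place. A modest step toward a lower number is therefore expected, a 1.5-fold lower number from compound 3 to compound 4 (0.18 log units; within the scatter), though a step within the scatter cannot be excluded. Compound 4 is estimated at 3 nM, with a range from 0.8 nM to 12 nM.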

Compound 4, inhibition constant: 0.63 nM
Beside the measured number, compound 4's estimate is 4.8-fold (0.68 log units) above it, and the stated range ends above it.
By their numbers in this assay, from the lowest: compounds 4 and 2 (each within the scatter of the next); then compound 3; then compound 1.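

On the sulfonyl sulfur, a ring with a hetero atom serves at least as well as either carbon-only ring: in this assay, exchanging 4-isopropylphenyl for 6-chloropyridin-3-yl gives a 7.1-fold lower number from compound 3 to compound 4 (0.85 log units; beyond the scatter), while the exchange for 3-methylphenyl gives a 1.4-fold lower number from compound 2 to compound 4 (0.15 log units; within the scatter). The replacement of the (2-(3-fluorophenyl)ethenyl)carbonyl group on the amine nitrogen with this sulfonyl group gives a 16-fold lower number from compound 1 to compound 4 (1.20 log units; beyond the scatter). Nothing measured here accounts for these steps. The compounds shown leave open whether the ring nitrogen or the chlorine matters more. A 4-chlorophenyl group or an unsubstituted pyridin-3-yl group on the sulfonyl sulfur would separate the two.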